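The source may report more compounds than this note shows. Statements on the series, on what has been measured and on what is new or still open speak of the compounds shown alone.

Working notes on the series.

Compound 2 `O=C(Nc1ccccc1C(F)(F)F)C1CCc2ccccc2N1` carries a free ring nitrogen. Within the data shown here, in a functional assay on PC-3 cells (Homo sapiens) for cytotoxicity, read by sulforhodamine B assay, with a stated time of 72 h (on this read-out lower numbers stand for stronger inhibition of growth and higher numbers for weaker inhibition of growth), compound 2 gives 53300 nM, the highest of the three numbers so far. Compound 1 `CCCC(=O)N1c2ccccc2CCC1C(=O)Nc1cc(C(F)(F)F)cc(C(F)(F)F)c1` gives 18600 nM and compound 3 `CCCCCCCCC(=O)N1c2ccccc2CCC1C(=O)Nc1cc(C(F)(F)F)cc(C(F)(F)F)c1` gives 7430 nM; neither differs from compound 2 in a single place, so those gaps are read only as what the two values show.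

Compound 4 `O=C(Nc1ccccc1C(F)(F)F)C1CCc2ccccc2N1C(=O)c1ccc(Cl)cc1` differs from compound 2 by (4-chlorophenyl)carbonyl in place of hydrogen on a nitrogen on an aromatic ring in a ring. Among the measured compounds shown here, no measured step matches this change directly. For the measured compounds named here, the one single-place step, a 2.5-fold lower number from compound 1 to compound 3 (0.40 log units; beyond the scatter), shows that a larger acyl chain on the ring nitrogen lowers the number, and the two acylated compounds 1 and 3 both sit below compound 2. Going by the values given here, on that basis a lower number is expected for compound 4 in this assay, by a step of about a 3.6-fold lower number from compound 2 to compound 4 (0.55 log units; beyond the scatter), with wide uncertainty since the aroyl group has no precedent here. The estimate for compound 4 is 15000 nM, range 4000 nM to 50000 nM.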

Compound 4, concentration for 50% growth inhibition: 786 nM
For compound 4 the middle estimate is 19-fold (1.28 log units) above the measured one, outside the stated range (below it).
By their numbers in this assay, from the lowest: compound 4; then compound 3; then compound 1; then compound 2.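

In this assay, acylation of the free ring nitrogen can now be read in a single place: (4-chlorophenyl)carbonyl in place of hydrogen gives a 68-fold lower number from compound 2 to compound 4 (1.83 log units; beyond the scatter). The earlier step, a 2.5-fold lower number from compound 1 to compound 3 (0.40 log units; beyond the scatter), changed only the length of a chain on a nitrogen that was already acylated, so it said nothing about replacing the hydrogen itself, and its size is far smaller than that of the new step. No measurement shown here bears on what lies behind this large step.

The compounds shown do not separate the contributions of the carbonyl, the aromatic ring and the chlorine, which an acetyl group, an unsubstituted benzoyl group or a 4-methoxybenzoyl group on the same nitrogen could address. Going by these compounds, it also remains open whether (4-chlorophenyl)carbonyl gives a similar step on the core of compound 1.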